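The source may hold more compounds than are shown below. What is called first, only, known or untested is meant among the compounds shown, and "the series" means these compounds.

Compound 3, `Cc1cc(NC(=O)OC(C)(C)C)nn1Cc1cc(Cl)ccc1OCc1ccccc1`, gives > 3.7 in a physicochemical assay for lipophilicity, at pH 7.4 (a higher number here means a more lipophilic compound, a lower number a more polar compound), which is a limit and not a number. Compound 4, `Cc1cc(NC(=O)OC(C)(C)C)nn1Cc1cc(Cl)ccc1OCC(C)C`, replaces its benzyloxy with isobutoxy: isopropyl in place of phenyl on a saturated chain carbon bound to an oxygen on an aromatic ring. Going by the values given here, no measured step covers this place. Compound 1, `Cc1cc(C(N)=O)nn1Cc1cc(Cl)ccc1OCC(C)C`, gives 3.1 in this assay. Among the compounds with values here, the only measured step, a number at least 0.60 log units higher from compound 1 to compound 2 (beyond the scatter), concerns another place, so it gives no size for this change. Compound 2, `Cc1cc(NC(=O)C2CCCCC2)nn1Cc1cc(Cl)ccc1OCC(C)C`, already carries isobutoxy and gives > 3.7, also a limit. Readings for compound 4 are therefore judged against (the limit of > 3.7 in this assay, at which 2 of the 3 values shown sit), and a limit is possible again. In this assay, the expected change, a step that the limit leaves unreadable from compound 3 to compound 4, is no step beyond the scatter. For compound 4 the estimated value is 3.8, with an expected range of 3.3 to 4.3.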

Compound 4, distribution coefficient: > 3.7
Compound 4: no number, only a limit; the forecaster's own chance of this, stated with the estimate: 60%; the middle value lies beyond the limit too.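

In this assay, (tert-butoxycarbonyl)amino in place of carbamoyl on an aromatic carbon gives a number at least 0.60 log units higher from compound 1 to compound 4 (beyond the scatter). This is a second replacement of carbamoyl to end beyond the scatter, alongside a number at least 0.60 log units higher from compound 1 to compound 2 (beyond the scatter). Compound 4 gives only a limit, and its steps from compound 2 and compound 3 cannot be read: the limit of > 3.7 in this assay, at which 3 of the 4 values shown sit.

From the compounds shown here alone, the size of any difference between isopropyl and phenyl on this saturated chain carbon remains open. So does whether an amine or a carboxylic acid in place of (tert-butoxycarbonyl)amino would give a number rather than a limit.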